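From 4-nitrophenyl to 3,5-dibromo-4-hydroxyphenyl in the series

A few compounds are considered here, and "the series" means these few. Any claim that something is new, unique, unknown or untested is made for them only; others in the source may bear on it.

Results so far in a functional assay on HeLa cells (Homo sapiens) for cytotoxicity, read by MTT assay, with a stated time of 72 h (on this read-out lower numbers stand for stronger inhibition and higher numbers for weaker inhibition), are as follows:
- compound 1 `O=C(/C=C/c1ccc([N+](=O)[O-])cc1)Nc1cc2c(Nc3ccc(F)c(Cl)c3)ncnc2cc1O[C@H]1CCOC1` — 27400 nM
- compound 2 `COc1ccc(OC)c(/C=C/C(=O)Nc2cc3c(Nc4ccc(F)c(Cl)c4)ncnc3cc2OC)c1` — "not determined" (no result reported)
- compound 3 `COc1ccc(/C=C/C(=O)Nc2cc3c(Nc4ccc(F)c(Cl)c4)ncnc3cc2OC)c(OC)c1` — "not determined" (no result reported)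

Going by the values given here, compound 1 at 27400 nM holds the only number available. Among the compounds with values here, compound 2 and compound 3 have no result, so compound 1 cannot be ranked against anything, and no measured step exists to calibrate a change.

Compound 4 `O=C(/C=C/c1cc(Br)c(O)c(Br)c1)Nc1cc2c(Nc3ccc(F)c(Cl)c3)ncnc2cc1O[C@H]1CCOC1` differs from compound 1 by 3,5-dibromo-4-hydroxyphenyl in place of 4-nitrophenyl on a double-bonded chain carbon bound to a double-bonded chain carbon in one place, with 3,5-dibromo-4-hydroxyphenyl in place of 4-nitrophenyl on a double-bonded chain carbon bound to a double-bonded chain carbon. Within the data shown here, the expectation in this assay is a modest move toward stronger inhibition, but it is tentative and rests on the single anchor of compound 1 at 27400 nM and the structural change alone. The expected size is a 2.3-fold lower number from compound 1 to compound 4 (0.36 log units; beyond the scatter) and it carries a wide margin. The estimate for compound 4 is 12000 nM with 3000 nM to 40000 nM as its expected range.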

Compound 4, half-maximal inhibitory concentration: 27700 nM
Compound 4: middle estimate off by 2.3-fold (0.36 log units), on the low side, and the stated range covers the measured number.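

In this assay, going by these compounds alone, 3,5-dibromo-4-hydroxyphenyl in place of 4-nitrophenyl on a double-bonded chain carbon bound to a double-bonded chain carbon gives a 1.0-fold higher number from compound 1 to compound 4 (0.00 log units; within the scatter), the first measured step. At this place, then, two aryl groups with different atoms and different hydrogen-bond donor counts are not told apart by this read-out. No data bearing on this result are available.

The bromines and the hydroxyl enter together in compound 4, so the part each plays on its own remains unresolved. Also open, on these data alone, is whether an amine or a carboxylic acid on the ring, or a longer chain in place of the 2-(4-nitrophenyl)ethenyl group, would give a number beyond the scatter from compound 1.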